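The compounds below may be only part of what the source reports. "The series", "measured", "known", "first", "only" and "open" are said of these compounds alone.

Three compounds share one core and differ only in the aromatic ring attached to it. Compound 1 `O=C(O)Cc1sc(C(c2ccc(F)cc2)c2ccc(F)cc2)nc1-c1ccccc1`, compound 2 `O=C(O)Cc1sc(C(c2ccc(F)cc2)c2ccc(F)cc2)nc1-c1ccco1` and compound 3 `COc1cc(-c2nc(C(c3ccc(F)cc3)c3ccc(F)cc3)sc2CC(=O)O)ccn1` were all tested in an in vitro assay on HEK385-7 cells for displacement of a labelled ligand from prostaglandin D2 receptor 2 (Homo sapiens); on this read-out lower numbers stand for stronger inhibition and higher numbers for weaker inhibition. In this assay compound 1 gives 16 nM, compound 2 gives 18 nM and compound 3 gives 29 nM. Compound 3 has the highest of the three numbers, but the steps leading to it, a 1.8-fold higher number from compound 1 to compound 3 (0.26 log units; within the scatter) and a 1.6-fold higher number from compound 2 to compound 3 (0.21 log units; within the scatter), both lie within the scatter, as does a 1.1-fold higher number from compound 1 to compound 2 (0.05 log units; within the scatter), so the three cannot be told apart. Compound 4 `O=C(O)Cc1sc(C(c2ccc(F)cc2)c2ccc(F)cc2)nc1-c1cn[nH]c1` is the next candidate; it differs from compound 3 by 1H-pyrazol-4-yl in place of 2-methoxypyridin-4-yl on an aromatic carbon. Within the data shown here, each measured step so far swaps one aromatic ring for another at this same place, and none moved the number beyond the scatter; a ring carrying a hydrogen-bond donor has not yet been tried, but the earlier swaps give no ground to expect a large step in either direction. Compound 4 is therefore expected to land close to compound 3, with an estimate of 22 nM and a range from 8 nM to 60 nM. The expected step from this estimate is a 1.3-fold lower number from compound 3 to compound 4 (0.12 log units; within the scatter).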

Compound 4, half-maximal inhibitory concentration: 16 nM
The estimate for compound 4 lay 1.4-fold (0.14 log units) above the measured number; the measured number falls inside the stated range.
By their numbers in this assay, from the lowest: compounds 1, 4, 2 and 3 (each within the scatter of the next).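

Compound 4 puts the first ring with a hydrogen-bond donor at this place, and in this assay it stays within the scatter of each earlier ring: 2-methoxypyridin-4-yl (a 1.8-fold lower number from compound 3 to compound 4 (0.26 log units; within the scatter)), furan-2-yl (a 1.1-fold lower number from compound 2 to compound 4 (0.05 log units; within the scatter)) and phenyl (no change at the digits printed from compound 1 to compound 4 (within the scatter)). So at this position, next to the ring nitrogen, adding a hydrogen-bond donor to the aromatic ring leaves the number within the scatter, across the five-membered and six-membered rings shown. Nothing measured here explains why these four rings read alike.

Still open, on these data alone, is whether the donor hydrogen of the pyrazole has any role of its own, which a 1-methyl-1H-pyrazol-4-yl ring would test. Also open, as far as these compounds go, is whether this place accepts something other than an aromatic ring, such as an amine or a longer carbon chain.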